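A few compounds are considered here, and "the series" means these few. Any claim that something is new, unique, unknown or untested is made for them only; others in the source may bear on it.

Compounds measured in a functional assay on KB cells (Homo sapiens) for cytotoxicity; on this read-out lower numbers stand for stronger inhibition and higher numbers for weaker inhibition:
- compound 1 `Cc1cccc(Cn2cc(C(N)=O)c3c(N)ncnc32)c1` gives > 100000 nM, which is a limit of the assay.
- compound 2 `C=CCn1cc(C(N)=S)c2c(N)ncnc21` gives 19000 nM.
- compound 3 `Cc1ccc(Cn2cc(C(N)=O)c3c(N)ncnc32)cc1` gives > 100000 nM, again a limit of the assay.

Compound 3 therefore stands only at a limit in this assay, and the same holds for compound 1, as the limit of > 100000 nM in this assay, at which 2 of the 3 values shown sit, records. For the measured compounds named here, the one step between measured compounds that differ in one place, a step that the two limits leave unreadable from compound 1 to compound 3, is unreadable, since both ends sit at that limit. Compound 2 is the only one of the three with a number rather than a limit.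

Compound 4 `C=CCn1cc(C(N)=O)c2c(N)ncnc21` is not yet measured. It differs from compound 3 by vinyl in place of 4-methylphenyl on a saturated chain carbon bound to an aromatic nitrogen. Going by the values given here, no measured step bears on this change directly. Compound 2 carries the same vinyl on that carbon but differs from compound 4 elsewhere, so its value can only be taken as a rough pointer. Compound 4 is thus expected to move off the limit by an at least 1.6-fold lower number from compound 3 to compound 4 (0.22 log units; that floor lies within the scatter), in the direction of stronger inhibition, though the expectation is weak and a limit remains a real possibility. The estimate for compound 4 in this assay is 60000 nM, with a range from 15000 nM to 300000 nM.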

Compound 4, half-maximal inhibitory concentration: 100000 nM
Compound 4: middle estimate off by 1.7-fold (0.22 log units), on the low side; the range from low to high includes it.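

For the compounds shown here, the first readable step lies on an aromatic carbon, not on the saturated chain carbon: with vinyl held constant, a group of 3 heavy atoms (1 carbon, 1 nitrogen, 1 oxygen; no ring) in place of a group of 3 heavy atoms (1 carbon, 1 nitrogen, 1 sulfur; no ring) gives in this assay a 5.3-fold higher number from compound 2 to compound 4 (0.72 log units; beyond the scatter). In this single pair, the sulfur-bearing group goes with the lower number and the oxygen-bearing group with the higher one, so the change on the aromatic carbon moves the read-out beyond the scatter. With vinyl in place of 4-methylphenyl, this assay shows a number no higher from compound 3 to compound 4 (the limit leaves the size open), and with vinyl in place of 3-methylphenyl it shows a number no higher from compound 1 to compound 4 (the limit leaves the size open). The size of these two steps cannot be read, as each has a limit at one end: the limit of > 100000 nM in this assay, at which 2 of the 4 values shown sit.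

As far as these compounds go, whether the sulfur-bearing group also lowers the number with 4-methylphenyl or 3-methylphenyl on the saturated chain carbon stays open. Also open, from the compounds shown here alone, is how a longer chain on that carbon, or a carboxylic acid on the aromatic carbon, would read in this assay.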